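A few compounds are considered here, and "the series" means these few. Any claim that something is new, unique, unknown or untested is made for them only; others in the source may bear on it.

Measured compounds:
Compound 1, `COc1ccc(/C=C\c2cc(OC)c(OC)c(OC)c2)cc1OCc1ccc(CN2C[C@H](O)C[C@@H]2C(=O)O)cc1`, gives > 10000 nM in a functional assay on B16-F10 cells (Mus musculus) for antiproliferative activity, read by CCK-8 assay, with a stated time of 48 h (on this read-out lower numbers stand for stronger inhibition and higher numbers for weaker inhibition), which is a limit of the assay rather than a number.
Compound 2, `COc1ccc(/C=C\c2cc(OC)c(OC)c(OC)c2)cc1OCc1ccc(CN2CC[C@H](C(=O)O)C2)cc1`, gives 7000 nM.
Compound 3, `COc1ccc(/C=C\c2cc(OC)c(OC)c(OC)c2)cc1OCc1ccc(CN2CC(C(=O)O)C2)cc1`, gives > 10000 nM, again only a limit.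

Compound 1 therefore stands at the limit, where two of the three values sit (the limit of > 10000 nM in this assay, at which 2 of the 3 values shown sit). Compound 4, `COc1ccc(/C=C\c2cc(OC)c(OC)c(OC)c2)cc1OCc1ccc(CNCCN(C)C)cc1`, differs from it in one place: (2-(dimethylamino)ethyl)amino in place of 2-carboxy-4-hydroxypyrrolidin-1-yl on a saturated chain carbon bound to an aromatic carbon. Two measured steps swap out the same group of compound 1: an at least 1.4-fold lower number from compound 1 to compound 2 (0.15 log units; that floor lies within the scatter) and a step that the two limits leave unreadable from compound 1 to compound 3. Both start from a limit, so neither gives a readable size. The change to compound 4 goes further, leaving no ring and no carboxy group, so a modest move to a lower number is expected, an at least 3.3-fold lower number from compound 1 to compound 4 (0.52 log units; beyond the scatter). The estimate for compound 4 is 3000 nM, ranging from 800 nM to 10000 nM.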

Compound 4, half-maximal inhibitory concentration: > 10000 nM
Compound 4: only a limit was reported (the forecaster's own chance of this, stated with the estimate: 30%); middle value at least 3.3-fold (0.52 log units) away from the limit.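

In this assay compound 4 gives > 10000 nM, which is a limit of the assay and not a number. Thus (2-(dimethylamino)ethyl)amino, with no ring and no carboxy group, gives no reading at this place on a saturated chain carbon bound to an aromatic carbon, and only compound 2 has a number: the limit of > 10000 nM in this assay, at which 3 of the 4 values shown sit. Among these compounds, the only readable step is an at least 1.4-fold higher number from compound 2 to compound 4 (0.15 log units; that floor lies within the scatter) and the others, each between two limits, cannot be read.

On these data alone, whether a morpholine ring, a plain primary amine or a carboxylic acid on a longer chain would give a number here stays open.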